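This account rests on a few compounds, and the source may have more. Where it says the series, first, only, none or still open, it means among the compounds named here.

Measured so far:
compound 1, `CC1=C(C(=O)OCc2ccccn2)C(c2ccc(Br)cc2)C2=C(CCCC2=O)N1`, in a physicochemical assay for lipophilicity, measured as octanol-water partition (a higher number here means a more lipophilic compound, a lower number a more polar compound), gives 2.42.
compound 2, `CC1=C(C(=O)OCc2cccnc2)C(c2ccc([N+](=O)[O-])cc2)C2=C(CCCC2=O)N1`, in this assay gives 1.51.

Compound 1 stands highest of the two numbers measured. Its nearest neighbour is compound 2, whose value lies lower by a margin beyond the usual scatter of this kind of measurement, so the two compounds are clearly told apart on this read-out. For the measured compounds named here, no step between two measured compounds that differ in one place only is available here, so the size of a single change has not been established within this set.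

The account now follows compound 1 to compound 3, `CC1=C(C(=O)OCc2ccccn2)C(c2cccs2)C2=C(CCCC2=O)N1`, which has not yet been measured. The structural change is thiophen-2-yl in place of 4-bromophenyl on a saturated ring carbon. Four-bromophenyl is replaced by thiophen-2-yl on a saturated ring carbon of the shared core; nothing else in the molecule is altered.

Going by the values given here, with no directly comparable step on record, the expectation rests on the size of the group that leaves and the one that enters. Compound 3 is expected to come out lower than compound 1, with an estimated step of a number 0.87 log units lower from compound 1 to compound 3 (beyond the scatter), beyond the scatter. For compound 3 the estimate is 1.55, within a range from 1.1 to 2.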

Compound 3, partition coefficient: 1.77
Beside the measured number, compound 3's estimate is 0.22 log units below it; measured number inside the range.
By their numbers in this assay, from the lowest: compounds 2 and 3 (each within the scatter of the next); then compound 1.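

For the compounds shown here, for the first time in this set, a change in one place can be read on its own: in this assay, thiophen-2-yl in place of 4-bromophenyl on the saturated ring carbon gives a number 0.65 log units lower from compound 1 to compound 3 (beyond the scatter) and so shows that the group at this carbon can move the read-out by more than the scatter. The exchange alters several counted features at once, since 7 heavy atoms give way to 5, a six-membered aromatic ring of carbon only gives way to a five-membered aromatic ring with 1 hetero atom, and bromine leaves while sulfur enters. The single step does not divide its size among these features, and no measured information accounts for it.

The compounds shown leave open how much of the step goes with the bromine and how much with the ring, a question that a plain phenyl group on this carbon would address. Also open, going by these compounds, is how the read-out would respond to a different kind of group here, such as an amine or a carboxylic acid.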